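The compounds below may be only part of what the source reports. "The series", "measured", "known", "first", "only" and "open" are said of these compounds alone.

Measured in a functional assay on HeLa cells (Homo sapiens) for antiproliferative activity, read by MTT assay, with a stated time of 48 h; a lower number here means a stronger inhibitor, a higher number a weaker inhibitor:
- compound 1 `Clc1ccc2[nH]c(-c3cn(-c4ccccc4)nc3-c3ccccc3)nc2c1`: 3480 nM
- compound 2 `Fc1ccc(-c2nn(-c3ccccc3)cc2-c2nc3ccccc3[nH]2)cc1`: 2330 nM
- compound 3 `Clc1ccc(-c2nn(-c3ccccc3)cc2-c2nc3ccccc3[nH]2)cc1`: 1650 nM

In this assay, compound 3 at 1650 nM lies within the scatter of compound 2, while compound 1 shows a number higher than compound 3 by more than the scatter. The next compound, compound 4 `Clc1ccc(-c2nn(-c3ccccc3)cc2-c2nc3cc(Cl)ccc3[nH]2)cc1`, has not yet been measured. It differs from compound 3 by one change: chloro in place of hydrogen on an aromatic carbon.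

Among the measured compounds shown here, no measured pair isolates this change. For the measured compounds named here, the only measured step, a 1.4-fold lower number from compound 2 to compound 3 (0.15 log units; within the scatter), swaps one halogen for another at a different place and stays within the scatter. Compound 1 has a chloro on the same carbon but lacks the chloro of compound 3, so it is not a clean comparison, although compound 1 at 3480 nM offers no sign that this chloro brings a large gain on its own. A step within or close to the scatter is therefore expected in this assay, leaning slightly towards a lower number. The expected change is a 1.3-fold lower number from compound 3 to compound 4 (0.10 log units; within the scatter). For compound 4 the estimated value is 1300 nM, with an expected range from 550 nM to 3100 nM.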

Compound 4, half-maximal inhibitory concentration: 1630 nM
Beside the measured number, compound 4's estimate is 1.3-fold (0.10 log units) below it; the range from low to high includes it.
By their numbers in this assay, from the lowest: compounds 4, 3, 2 and 1 (each within the scatter of the next, the first and the last beyond it).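

In this assay, chloro in place of hydrogen on an aromatic carbon of the six-membered aromatic ring of carbon only, part of a fused or bridged system of two rings, gives a step that stays within the scatter (a 1.0-fold lower number from compound 3 to compound 4 (0.01 log units; within the scatter)), so the assay does not separate the hydrogen from the chloro at this position when compound 3 is the starting point. Among the compounds shown here, the second chloro of compound 4, the one that compound 1 lacks, can now be read on its own with the chloro on the fused system present on both sides, and this step passes the scatter, though only modestly (a 2.1-fold lower number from compound 1 to compound 4 (0.33 log units; beyond the scatter)). Nothing measured bears on either step, so the numbers stand without an explanation.

Going by these compounds, whether a group other than chloro, such as an amine or a carboxylic acid, would move the number at this carbon remains open, since only hydrogen and chloro are seen there. Also open, on these data alone, is how a methoxy group would compare with the fluoro of compound 2 and the chloro of compound 3.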